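Swapping the Aryl Group on a Shared Acid Core

The source may report more compounds than this note shows. Statements on the series, on what has been measured and on what is new or still open speak of the compounds shown alone.

Compound 1 `COc1cc(-c2nc(C(c3ccc(F)cc3)c3ccc(F)cc3)sc2CC(=O)O)ccn1` in this assay: 29 nM
Compound 2 `COc1ccc(OC)c(-c2nc(C(c3ccccc3)c3ccccc3)sc2CC(=O)O)c1` in this assay: > 105 nM

Both compounds were tested in an in vitro assay on HEK385-7 cells for displacement of a labelled ligand from prostaglandin D2 receptor 2 (Homo sapiens); on this read-out higher numbers stand for weaker inhibition and lower numbers for stronger inhibition. Within the data shown here, compound 1 gives 29 nM, the only true number among the two values shown. Compound 2 gives > 105 nM, which is a limit of the assay rather than a number (the limit of > 105 nM in this assay, at which 1 of the 2 values shown sits). Among the measured compounds shown here, compound 1 and compound 2 differ in more than one place, so no measured step between them is available to guide the next change.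

Compound 3 `N#Cc1ccc(-c2nc(C(c3ccc(F)cc3)c3ccc(F)cc3)sc2CC(=O)O)cc1` differs from compound 1 in a single place (4-cyanophenyl in place of 2-methoxypyridin-4-yl on an aromatic carbon). Without a measured step of this kind, the expectation rests on compound 1 alone, and the change is expected to shift the value by no more than the usual scatter, giving an estimated step of a 1.4-fold higher number from compound 1 to compound 3 (0.14 log units; within the scatter). Compound 3 is therefore estimated at 40 nM, within a range of 10 nM to 160 nM.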

Compound 3, half-maximal inhibitory concentration: 150 nM
The estimate for compound 3 lay 3.8-fold (0.57 log units) below the measured number, and the stated range covers the measured number.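

In this assay, placing 4-cyanophenyl in place of 2-methoxypyridin-4-yl on the aromatic carbon next to the ring nitrogen gives a 5.2-fold higher number from compound 1 to compound 3 (0.71 log units; beyond the scatter), meaning weaker inhibition and the only single-place step shown. This position therefore does not treat all six-membered aromatic rings alike, even though the two groups count the same number of heavy atoms. Nothing measured here explains why the inhibition weakens.

The swap removes the ring nitrogen and the methoxy group and adds the nitrile all at once, and the step does not tell which of these changes counts. Going by these compounds, a 4-methoxyphenyl or an unsubstituted pyridin-4-yl group on the same carbon would help separate them, and how either would compare with compound 1 remains open.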